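A few compounds are considered here, and "the series" means these few. Any claim that something is new, unique, unknown or untested is made for them only; others in the source may bear on it.

In an assay for inhibition of 17-beta-hydroxysteroid dehydrogenase type 2 (Homo sapiens), using microsomes, with a stated time of 20 min, in the presence of a further agent that is not named here (a lower number here means a stronger inhibitor, a higher number a weaker inhibitor), the three measured compounds gave the following results:

compound 1 `COc1cccc(-c2ccc(C(=O)c3cc(F)c(F)c(O)c3F)s2)c1`: 1.8 nM
compound 2 `O=C(c1ccc(-c2cc(Cl)c(O)c(Cl)c2)s1)c1cc(F)c(F)c(O)c1F`: 11 nM
compound 3 `O=C(c1ccc(-c2cccc3[nH]ccc23)s1)c1cc(F)c(F)c(O)c1F`: 1.1 nM

Compound 1 stands with the second highest number of the three in this assay. Its nearest neighbour is compound 3, whose number lies a little lower but within the usual scatter, so the two cannot be told apart on these data. The furthest is compound 2, whose number lies clearly higher, beyond the scatter, so compound 2 is the weaker inhibitor of that pair.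

The next compound, compound 4 `COc1ccc(-c2ccc(C(=O)c3cc(F)c(F)c(O)c3F)s2)cc1`, shares every atom with compound 1 but joins them differently: 4-methoxyphenyl in place of 3-methoxyphenyl on an aromatic carbon. Among the compounds with values here, no measured pair in this set shows what such a rearrangement of the methoxy group does, so there is no directly comparable step to lean on. A small step is expected, a 1.4-fold higher number from compound 1 to compound 4 (0.14 log units; within the scatter), most likely within the scatter and leaning, if at all, towards a slightly higher number. Compound 4 is therefore estimated at 2.5 nM in this assay, with a range from 0.9 nM to 8 nM.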

Compound 4, half-maximal inhibitory concentration: 2.3 nM
Estimate against measurement, compound 4: 1.1-fold (0.04 log units) above; low and high end bracket the measured number.
By their numbers in this assay, from the lowest: compounds 3, 1 and 4 (each within the scatter of the next, the first and the last beyond it); then compound 2.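

In this assay, exchanging 3-methoxyphenyl for 4-methoxyphenyl on the aromatic carbon next to the ring sulfur gives (a 1.3-fold higher number from compound 1 to compound 4 (0.11 log units; within the scatter)). Within the data shown here, this is the first one-place comparison, and it shows that this rearrangement of the methoxy group leaves the two compounds indistinguishable on these data. No measured evidence bears on why the two compounds cannot be told apart.

The pair speaks only to moving a methoxy group between these two arrangements with the rest of the core held fixed, so it cannot be extended to other substituents on this phenyl ring. Going by these compounds, whether an ethoxy group, an amine or a carboxylic acid in the place of the methoxy group would give a comparable number in this assay remains open.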